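This account rests on a few compounds, and the source may have more. Where it says the series, first, only, none or still open, it means among the compounds named here.

Working notes on the series. In a functional assay on HCT-116 cells (Homo sapiens) for inhibition, read by MTT assay, with a stated time of 72 h (a higher number here means a weaker inhibitor, a lower number a stronger inhibitor), compound 1 (`Cc1cc(C)cc(CN2CCc3ncn(COCc4ccccc4)c3/C(=C/c3ccccc3)C2=O)c1`) gives 6230 nM, compound 3 (`CC(C)(C)c1ccc(CN2CCc3ncn(COCc4ccccc4)c3/C(=C/c3ccccc3)C2=O)cc1`) gives 8460 nM, and compound 2 (`O=C1/C(=C\c2ccccc2)c2c(ncn2COCc2ccccc2)CCN1Cc1ccc(-c2ccccc2)cc1`) gives 14000 nM. Compound 1 sits at the low end of these three numbers, together with compound 3.

The next comparison is with compound 4 (`O=C1/C(=C\c2ccccc2)c2c(ncn2COCc2ccccc2)CCN1Cc1ccc2ccccc2c1`), which has not yet been measured in this assay. The change is naphthalen-2-yl in place of 3,5-dimethylphenyl on a saturated chain carbon bound to an amide-type nitrogen in a ring.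

Two measured changes at this same place bear on it. With 4-phenylphenyl entering, the result is a 2.2-fold higher number from compound 1 to compound 2 (0.35 log units; beyond the scatter). With 4-(tert-butyl)phenyl entering, the result is a 1.4-fold higher number from compound 1 to compound 3 (0.13 log units; within the scatter). The comparison between those two replacements gives a 1.7-fold lower number from compound 2 to compound 3 (0.22 log units; within the scatter). Neither replacement is a close match for naphthalen-2-yl, and the series holds too few compounds to define a trend.

A small upward step is therefore expected, on the basis of compound 3 with a 1.4-fold higher number from compound 1 to compound 3 (0.13 log units; within the scatter) and compound 2 with a 2.2-fold higher number from compound 1 to compound 2 (0.35 log units; beyond the scatter), and it may not clear the scatter. The estimated change is a 1.4-fold higher number from compound 1 to compound 4 (0.13 log units; within the scatter). For compound 4 the expected value is 8500 nM, with an estimated range of 4500 nM to 16000 nM.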

Compound 4, half-maximal inhibitory concentration: 19400 nM
Compound 4: middle estimate off by 2.3-fold (0.36 log units), on the low side, and the stated range ends below it.
By their numbers in this assay, from the lowest: compounds 1, 3, 2 and 4 (each within the scatter of the next, the first and the last beyond it).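

For the compounds shown here, the aryl group at this place on the saturated chain carbon matters more than the earlier compounds showed: in this assay, naphthalen-2-yl in place of 3,5-dimethylphenyl gives the widest step seen here (a 3.1-fold higher number from compound 1 to compound 4 (0.49 log units; beyond the scatter)). The result also separates two replacements by more than the scatter (a 2.3-fold higher number from compound 3 to compound 4 (0.36 log units; beyond the scatter)), which the step between compound 2 and compound 3 did not do for 4-phenylphenyl and 4-(tert-butyl)phenyl. Naphthalen-2-yl and 4-phenylphenyl, the two groups with two aromatic rings, cannot be told apart (a 1.4-fold higher number from compound 2 to compound 4 (0.14 log units; within the scatter)), and both lie beyond the scatter from compound 1, although compound 3 blurs any clean split by standing within the scatter of both compound 1 and compound 2. No available evidence accounts for this result.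

From the compounds shown here alone, with only four compounds, all carrying carbon-only aryl groups, it remains open whether the two-ring pattern would hold for naphthalen-1-yl or an unsubstituted phenyl. Going by these compounds, how an amine or a carboxylic acid on this aryl group would read in this assay also remains open.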